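Ethylamino in place of chloro on the shared core

The compounds below may be only part of what the source reports. "The series", "measured", "known", "first", "only" and "open" are said of these compounds alone.

In a functional assay on NB1 cells (Homo sapiens) for cytotoxicity, read by MTT assay, with a stated time of 3 days (a lower number here means a stronger inhibitor, a higher number a weaker inhibitor), three compounds have numbers: compound 1 `N#Cc1c(O)nc(SCc2nc3ccccc3[nH]2)nc1-c1ccccc1` at (6.57 nM), compound 2 `N#Cc1c(Cl)nc(SCc2nc3ccccc3[nH]2)nc1-c1ccccc1` at (2.87 nM) and compound 3 `CNc1nc(SCc2nc3ccccc3[nH]2)nc(-c2ccccc2)c1C#N` at (4.46 nM). Compound 2 stands at the low end of these numbers. It is separated from compound 1 beyond the scatter (a 2.3-fold lower number from compound 1 to compound 2 (0.36 log units; beyond the scatter)), but not from compound 3 (a 1.6-fold higher number from compound 2 to compound 3 (0.19 log units; within the scatter)).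

Compound 4 `CCNc1nc(SCc2nc3ccccc3[nH]2)nc(-c2ccccc2)c1C#N` carries ethylamino in place of chloro on an aromatic carbon. The nearest measured guide is the methylamino in place of chloro step to compound 3 (a 1.6-fold higher number from compound 2 to compound 3 (0.19 log units; within the scatter)), which lies within the scatter. Methylamino in place of hydroxy (a 1.5-fold lower number from compound 1 to compound 3 (0.17 log units; within the scatter)) also lies within it. Within the data shown here, no measured pair compares ethylamino with methylamino directly, so that extension remains untested. In this assay the expected step is therefore none beyond the scatter (a 1.6-fold higher number from compound 2 to compound 4 (0.20 log units; within the scatter)). The estimated value for compound 4 is 4.5 nM (expected range 2.2 nM to 9.5 nM).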

Compound 4, half-maximal inhibitory concentration: 2.63 nM
Compound 4: middle estimate off by 1.7-fold (0.23 log units), on the high side; low and high end bracket the measured number.
By their numbers in this assay, from the lowest: compounds 4, 2, 3 and 1 (each within the scatter of the next, the first and the last beyond it).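

In this assay, the position takes ethylamino, with 3 heavy atoms and a hydrogen-bond donor, in place of chloro with no separation beyond the scatter (a 1.1-fold lower number from compound 2 to compound 4 (0.04 log units; within the scatter)). Among these compounds, the methyl added to methylamino, a comparison the earlier compounds lacked, also stays within the scatter (a 1.7-fold lower number from compound 3 to compound 4 (0.23 log units; within the scatter)), while ethylamino in place of hydroxy is a modest step beyond it (a 2.5-fold lower number from compound 1 to compound 4 (0.40 log units; beyond the scatter)). Chloro, methylamino and ethylamino are therefore not separated from one another here, and hydroxy stands apart from chloro and ethylamino but not from methylamino (a 1.5-fold lower number from compound 1 to compound 3 (0.17 log units; within the scatter)).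

Going by these compounds, whether a longer chain such as butylamino, a cyclic amine such as morpholine or a carboxylic acid at this position would stay with these numbers remains open. No measurement at hand accounts for these numbers.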